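Replacing a Formyl Group in a Flat Series

The source may report more compounds than this note shows. Statements on the series, on what has been measured and on what is new or still open speak of the compounds shown alone.

In a functional assay on MCF7 cells (Homo sapiens) for antiproliferative activity, read by MTT assay, with a stated time of 48 h (a lower number here means a stronger inhibitor, a higher number a weaker inhibitor), compound 1 `COC/C1=C/C[C@](C)(CCC=C(C)C)/C=C/[C@@H](OC(=O)C=C(C)C)[C@](C)(OC)/C=C/C1=O` gives 16500 nM, compound 2 `CO[C@]1(C)/C=C/C(=O)/C(CO)=C\C[C@](C)(CCC=C(C)C)/C=C/[C@H]1OC(=O)C=C(C)C` gives 14300 nM and compound 3 `CC(C)=CCC[C@]1(C)/C=C/[C@@H](OC(=O)C=C(C)C)[C@](C)(O)/C=C/C(=O)/C(C=O)=C\C1` gives 12600 nM, so compound 3 stands level with the other two, within the scatter. Compound 4 `CC(C)=CCC[C@]1(C)/C=C/[C@@H](OC(=O)C=C(C)C)[C@](C)(O)/C=C/C(=O)/C(CN(C)C)=C\C1` carries (dimethylamino)methyl in place of formyl on a double-bonded ring carbon. Within the data shown here, the only measured single change, a 1.2-fold lower number from compound 1 to compound 2 (0.06 log units; within the scatter), puts hydrogen in place of methyl on an oxygen on a saturated carbon. It is a different change, so it bears on this one only weakly, and no measurement tests this replacement directly. The estimate is a 1.3-fold lower number from compound 3 to compound 4 (0.10 log units; within the scatter), so no step beyond the scatter is expected in this assay. Compound 4 is expected at 10000 nM, with an estimated range of 3500 nM to 26000 nM.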

Compound 4, half-maximal inhibitory concentration: 690 nM
Estimate against measurement, compound 4: 14-fold (1.16 log units) above; the measured number lies below the stated range.
By their numbers in this assay, from the lowest: compound 4; then compounds 3, 2 and 1 (each within the scatter of the next).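

Compounds 1, 2 and 3 stand level and gave no sign that any change affects activity. This double-bonded ring carbon now proves sensitive in this assay: (dimethylamino)methyl in place of formyl gives an 18-fold lower number from compound 3 to compound 4 (1.26 log units; beyond the scatter). Formyl is therefore not required on this carbon for antiproliferative activity in this pair, and replacing it can bring a large gain.

On these data alone, whether another amine, such as a pyrrolidin-1-ylmethyl group, or a carboxylic acid on this carbon would behave alike remains open. Nothing available explains the size of this step.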